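The compounds below may be only part of what the source reports. "The series", "measured", "known", "first", "only" and "open" are said of these compounds alone.

Compound 2, with the structure `N#Cc1ccc(COc2ccc(-c3cc(CN4CCN(Cc5ccc(C(F)(F)F)cc5)CC4)no3)cc2)cc1`, and compound 1, with the structure `Cc1ccc(COc2ccc(-c3cc(CN4CCN(Cc5ccc(C(F)(F)F)cc5)CC4)no3)cc2)cc1`, share one core and differ only at the ring on the benzyl group. In a functional assay on Huh-7 cells (Homo sapiens) for antiproliferative activity, read by sulforhodamine B assay, with a stated time of 72 h (a higher number here means a weaker inhibitor, a lower number a stronger inhibitor), compound 1 gives 1500 nM, and compound 2 gives 1000 nM; the step of a 1.5-fold lower number from compound 1 to compound 2 (0.18 log units; within the scatter) shows the two numbers lie within the scatter of each other, so compound 2 has the lower of the two numbers without standing apart from compound 1.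

Compound 3, with the structure `COc1cc(COc2ccc(-c3cc(CN4CCN(Cc5ccc(C(F)(F)F)cc5)CC4)no3)cc2)cc(OC)c1`, carries the change (3,5-dimethoxyphenyl in place of 4-cyanophenyl on a saturated chain carbon bound to an oxygen on an aromatic ring). Within the data shown here, the only measured step at this position is a 1.5-fold lower number from compound 1 to compound 2 (0.18 log units; within the scatter), a small change when one small group replaced another on that ring; here a larger replacement comes in, and no measured pair shows how it reads. The step of a 1.2-fold higher number from compound 2 to compound 3 (0.08 log units; within the scatter) is therefore expected to stay near the scatter, and compound 3 is estimated at 1200 nM, within 400 nM to 4000 nM.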

Compound 3, half-maximal inhibitory concentration: 1500 nM
Compound 3: middle estimate off by 1.3-fold (0.10 log units), on the low side, and the stated range covers the measured number.
By their numbers in this assay, from the lowest: compounds 2, 1 and 3 (each within the scatter of the next).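

In this assay, the replacement of 4-cyanophenyl, with 8 heavy atoms, by 3,5-dimethoxyphenyl, with 10 heavy atoms and two methoxy groups rather than a single nitrile, stays within the scatter (a 1.5-fold higher number from compound 2 to compound 3 (0.18 log units; within the scatter)). The replacement of 4-methylphenyl by the same 3,5-dimethoxyphenyl group also stays within the scatter (no change at the digits printed from compound 1 to compound 3 (within the scatter)), so this position has now taken a larger group with two ring substituents, and all three compounds still read alike. No measurement available here explains why these numbers remain so close.

On these data alone, it remains open whether an amine or a carboxylic acid on this ring would give a number beyond the scatter. A longer chain between this ring and the oxygen also remains an open case.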